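Aryl Swap on an Oxazole Amide: Cytotoxicity Outlook

The compounds below may be only part of what the source reports. "The series", "measured", "known", "first", "only" and "open" are said of these compounds alone.

Measured compounds:
compound 1, `Cc1oc(-c2c(Cl)cccc2C(F)(F)F)nc1CN1CCC(C(=O)NCCCN2C[C@H](C)C[C@H](C)C2)CC1`, 12000 nM
compound 2, `CCc1ccccc1-c1nc(CN2CCC(C(=O)NCCCN3C[C@H](C)C[C@H](C)C3)CC2)c(C)o1`, 9320 nM

In an ADME assay on Huh7.5.1 cells (Homo sapiens) for cytotoxicity, read by ATP content, with a stated time of 48 h (a lower number here means that less compound is tolerated, a higher number that more compound is tolerated), compound 2 gives 9320 nM, the lowest of the two numbers, with compound 1 as its nearest neighbour: a 1.3-fold lower number from compound 1 to compound 2 (0.11 log units; within the scatter). Compound 3, `COc1ccc(-c2nc(CN3CCC(C(=O)NCCCN4C[C@H](C)C[C@H](C)C4)CC3)c(C)o2)cc1OC`, has not been measured. It differs from compound 2 at the aryl group on the shared core: 3,4-dimethoxyphenyl in place of 2-ethylphenyl on an aromatic carbon. Among the measured compounds shown here, the only step measured so far, the one from compound 1 to compound 2, also exchanged this aryl group and stayed within the scatter. On that basis a change beyond the scatter in this assay is not expected for compound 3, with an estimated step of a 1.3-fold higher number from compound 2 to compound 3 (0.11 log units; within the scatter). Compound 3 is therefore expected to give about 12000 nM, within a range of 5000 nM to 30000 nM.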

Compound 3, half-maximal cytotoxic concentration: 57200 nM
Beside the measured number, compound 3's estimate is 4.8-fold (0.68 log units) below it; the measured number lies above the stated range.
By their numbers in this assay, from the lowest: compounds 2 and 1 (each within the scatter of the next); then compound 3.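

In this assay, the aryl group on the shared core can move the number beyond the scatter: 3,4-dimethoxyphenyl gives a 6.1-fold higher number from compound 2 to compound 3 (0.79 log units; beyond the scatter) and a 4.8-fold higher number from compound 1 to compound 3 (0.68 log units; beyond the scatter), whereas the exchange between the two earlier aryl groups gave only a 1.3-fold lower number from compound 1 to compound 2 (0.11 log units; within the scatter). The position is therefore not indifferent to this exchange, and more compound is tolerated with 3,4-dimethoxyphenyl than with either 2-ethylphenyl or 2-chloro-6-(trifluoromethyl)phenyl. No measurement at hand accounts for the rise.

The change from compound 2 to compound 3 both removes the 2-ethyl group and adds the two methoxy groups, so the compounds shown do not tell which of these matters, or whether both do. Nor do they show whether a single methoxy group, a hydroxyl group or an amine on the phenyl ring would give a similar number.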